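Notes on a sulfonamide series: cyclopropyl to cyclopentyl

This account rests on a few compounds, and the source may have more. Where it says the series, first, only, none or still open, it means among the compounds named here.

Measured so far in a functional assay on MV4-11 cells (Homo sapiens) for inhibition, with a stated time of 72 h; a higher number here means a weaker inhibitor, a lower number a stronger inhibitor:
compound 1 `O=C(NO)c1ccc2c(c1)CCN(S(=O)(=O)c1cc(F)c(F)c(F)c1F)C2`, 900 nM
compound 2 `O=C(NO)c1ccc(CN(C2CC2)S(=O)(=O)c2cc(F)c(F)c(F)c2F)cc1`, 400 nM
compound 3 `CC(C)N(Cc1ccc(C(=O)NO)cn1)S(=O)(=O)c1cc(F)c(F)c(F)c1F`, 1000 nM

Of the three, compound 2 stands lowest in this assay, and its steps to compound 1 and to compound 3 both lie beyond the usual scatter, so compound 2 is the most potent of the measured set. Within the data shown here, compound 1 and compound 3 each differ from compound 2 in more than one place, and no single-point step between measured compounds is available, so the numbers give no guide to how one change on the sulfonamide nitrogen alone shifts the read-out.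

Compound 4 `O=C(NO)c1ccc(CN(C2CCCC2)S(=O)(=O)c2cc(F)c(F)c(F)c2F)cc1` has not yet been measured. It differs from compound 2 as follows: cyclopentyl in place of cyclopropyl on a sulfonamide nitrogen. The change keeps the count of donors and acceptors and the charge unchanged and only enlarges the ring on that nitrogen. Among the measured compounds shown here, with no comparable step on record, the expectation is a modest shift, possibly none beyond the scatter, with the direction open. The expected step in this assay is a 1.1-fold higher number from compound 2 to compound 4 (0.05 log units; within the scatter). For compound 4 the estimate in this assay is 450 nM, within a range from 150 nM to 1300 nM.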

Compound 4, half-maximal inhibitory concentration: 2710 nM
Compound 4: middle estimate off by 6.0-fold (0.78 log units), on the low side; measured number outside the range, above it.
By their numbers in this assay, from the lowest: compound 2; then compounds 1 and 3 (each within the scatter of the next); then compound 4.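

Among these compounds, this is the first single-point step: in this assay, cyclopentyl in place of cyclopropyl on a sulfonamide nitrogen gives a 6.8-fold higher number from compound 2 to compound 4 (0.83 log units; beyond the scatter). The two groups are both rings of carbon only, with 3 heavy atoms leaving, 5 heavy atoms entering, and no hydrogen-bond donors, acceptors or net charge on either side, so this position is shown to be sensitive to a change confined to the ring on that nitrogen, and the read-out favours the cyclopropyl of compound 2 over the cyclopentyl of compound 4. No measured property or other supporting data on these compounds accounts for the size of this step.

A single pair cannot show whether the read-out follows ring size gradually or changes abruptly, and a cyclobutyl on the same nitrogen of this core would help separate the two. Also open, as far as these compounds go, is whether a larger ring can be tolerated when it carries a hydroxyl group or an amine, or whether a short open chain such as ethyl behaves like either ring.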